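Fluorine removal beside the methoxy group of compound 2

The compounds below may be only part of what the source reports. "The series", "measured", "known", "first", "only" and "open" are said of these compounds alone.

Three compounds of the series carry numbers in an assay on isolated protein for inhibition of N-acylethanolamine-hydrolyzing acid amidase (Homo sapiens), read by fluorescence, with a stated time of 90 min; a higher number here means a weaker inhibitor, a lower number a stronger inhibitor. Compound 1 `S=C=N[C@H]1C[C@H](OCc2ccc(-c3ccccc3)cc2)C1` gives 4300 nM. Compound 3 `COc1ccc(-c2ccc(CO[C@H]3C[C@@H](N=C=S)C3(C)C)nc2)cc1F` gives 246 nM. Compound 2 `COc1ccc(-c2ccc(S(=O)(=O)N[C@H]3C[C@@H](N=C=S)C3)cc2)cc1F` gives 3.2 nM, the lowest of the three: compound 3 stands nearest to it, beyond the scatter, and compound 1 furthest, also beyond the scatter. No pair among these three differs in only one place, so no single step between measured compounds is known.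

Compound 4 `COc1ccc(-c2ccc(S(=O)(=O)N[C@H]3C[C@@H](N=C=S)C3)cc2)cc1` has no number yet. It differs from compound 2 in one place: hydrogen in place of fluoro on an aromatic carbon, ortho to a methoxy group and meta to a large group; the rest of compound 2 is kept. Among the measured compounds shown here, with no comparable step to lean on, the step from compound 2 to compound 4 is expected to be small, if anything toward a higher number, and possibly not beyond the scatter. Compound 4 is expected to give 6 nM, with a range from 2 nM to 20 nM. That corresponds to an expected step of a 1.9-fold higher number from compound 2 to compound 4 (0.27 log units; within the scatter).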

Compound 4, half-maximal inhibitory concentration: 2.3 nM
Estimate against measurement, compound 4: 2.6-fold (0.42 log units) above; the measured number falls inside the stated range.
By their numbers in this assay, from the lowest: compounds 4 and 2 (each within the scatter of the next); then compound 3; then compound 1.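

In this assay, hydrogen in place of fluoro on an aromatic carbon, ortho to a methoxy group and meta to a large group, gives a 1.4-fold lower number from compound 2 to compound 4 (0.14 log units; within the scatter). Among the compounds shown here, this is the first single-place step, and it shows that the fluoro can leave this position without a change beyond the scatter, so compound 2 and compound 4 cannot be told apart here. No measurement at hand bears on why this step is so slight.

On these data alone, only fluoro and hydrogen have been compared at this position, so it remains open whether a chloro group, a nitrile or an amine there would hold the number. As far as these compounds go, it is also open whether the same step would be as slight on compound 3, which carries the same fluoro on a different core.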